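The compounds below may be only part of what the source reports. "The series", "measured", "known", "first", "only" and "open" are said of these compounds alone.

Two compounds in this set carry measurements. Compound 1 `COc1cc(Cl)cc(-c2nn(-c3cccc(NC(=O)Nc4cccc(C(F)(F)F)c4)c3)cc2-c2ccncc2)c1` gives 94% in a functional assay on OVCAR-5 cells (Homo sapiens) for inhibition, read by sulforhodamine B assay, with a stated time of 48 h, tested at 0.01 uM; on this read-out lower numbers stand for a stronger effect and higher numbers for a weaker effect at the one concentration tested. Compound 2 `COc1cc(Cl)cc(-c2nn(-c3cccc(NC(=O)Nc4ccc(Cl)c(C(F)(F)F)c4)c3)cc2-c2ccncc2)c1` gives 54% in this assay. Within the data shown here, the single one-place step between them, a number 40 percentage points lower from compound 1 to compound 2 (beyond the scatter), leaves compound 2 standing at the lowest of the two numbers, its nearest neighbour being compound 1, which lies beyond the scatter above it.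

Compound 3 `O=C(Nc1cccc(-n2cc(-c3ccncc3)c(-c3cc(O)cc(Cl)c3)n2)c1)Nc1ccc(Cl)c(C(F)(F)F)c1` is the next step out from compound 2: hydrogen in place of methyl on an oxygen on an aromatic ring. Among the measured compounds shown here, no measured step bears on this change. For the measured compounds named here, the only step recorded concerns a different group, the chloro entering in place of hydrogen, and its size offers no guide to what the loss of the methyl will do. With nothing in the data pointing either way, compound 3 is expected to give a number within the scatter of its parent, an expected step of no change at the digits printed from compound 2 to compound 3 (within the scatter). The estimate for compound 3 in this assay is 54%, with a range from 32% to 78%.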

Compound 3, a percentage reported as activity, at one concentration (the size of the read-out at that concentration, not a potency): 98%
The estimate for compound 3 lay 44 percentage points below the measured number; measured number above the stated range.
By their numbers in this assay, from the lowest: compound 2; then compounds 1 and 3 (each within the scatter of the next).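

In this assay, among these compounds, this is the first change at the oxygen on the aromatic ring, and it shows that the position is far from silent: methoxy to hydroxy gives a number 44 percentage points higher from compound 2 to compound 3 (beyond the scatter). The earlier step concerned only a chloro entering on an aromatic carbon elsewhere in the structure, whereas compound 3 keeps that chloro and still gives 98%, so at the one concentration tested the chloro alone does not secure the stronger effect of compound 2, and the methyl on this oxygen is needed alongside it. Nothing measured here explains why the loss of a single methyl has a step of this size.

The compounds shown leave open whether the methoxy is the only group at this place that keeps the stronger effect, or whether an ethoxy, a longer alkoxy chain or an amine would do the same. They also leave open whether the same change would give a step of this size on the structure of compound 1, which lacks the added chloro.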